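Chloro substitution on the fused ring of a tetrahydroquinolinol series

This account rests on a few compounds, and the source may have more. Where it says the series, first, only, none or still open, it means among the compounds named here.

The shared core is a fused bicyclic amino alcohol carrying a second aryl ring; the four members differ only in the halogen pattern on those two rings. Compound 1 `O[C@@H]1Cc2ccccc2N[C@H](c2ccccc2F)C1` bears a single fluoro on the pendant ring. Compound 2 `O[C@@H]1Cc2cc(Cl)ccc2N[C@H](c2ccccc2F)C1` adds a chloro to the fused ring. Compound 3 `O[C@@H]1Cc2ccccc2N[C@H](c2c(Cl)cccc2Cl)C1` carries two chloro groups on the pendant ring, and compound 4 `O[C@@H]1Cc2cc(Cl)ccc2N[C@H](c2c(Cl)cccc2Cl)C1` combines that pattern with the chloro on the fused ring; compound 4 is not yet measured. The difference between the core of compound 1 and the core of compound 3 is not broken down here.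

In an ADME assay on Vero cells (Chlorocebus sabaeus) for cytotoxicity, read by MTT assay, with a stated time of 72 h (a higher number here means that more compound is tolerated, a lower number that less compound is tolerated), compound 1 reaches only a limit, > 300000 nM. In this assay compound 2 gives 182000 nM. For compound 3 this assay again reports a limit, > 300000 nM. The change from compound 1 to compound 2 is chloro in place of hydrogen on an aromatic carbon, and it produced an at least 1.6-fold lower number from compound 1 to compound 2 (0.21 log units; that floor lies within the scatter).

The change from compound 3 to compound 4 is chloro in place of hydrogen on an aromatic carbon, the same change as that from compound 1 to compound 2. Since two of the three values shown sit at the limit (the limit of > 300000 nM in this assay, at which 2 of the 3 values shown sit), a result at that limit remains possible for compound 4. Taking the step seen from compound 1 to compound 2 as the guide, the step from compound 3 to compound 4 in this assay is expected to be an at least 1.5-fold lower number from compound 3 to compound 4 (0.17 log units; that floor lies within the scatter). Compound 4 is therefore estimated at 200000 nM, with a range from 90000 nM to 300000 nM.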

Compound 4, half-maximal cytotoxic concentration: 49900 nM
Estimate against measurement, compound 4: 4.0-fold (0.60 log units) above, outside the stated range (below it).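

In this assay, chloro in place of hydrogen on an aromatic carbon gives an at least 6.0-fold lower number from compound 3 to compound 4 (0.77 log units; beyond the scatter), so on the core of compound 3 the change brings a lower number by a step that stands clear of the scatter. On the core of compound 1 the same change has only a floor that lies within the scatter, so the pair shows neither that the step carries over at a fixed size nor that its size depends on the core: the same change on two cores in this assay, an at least 1.6-fold lower number (0.21 log units; that floor lies within the scatter) from compound 1 to compound 2 and an at least 6.0-fold lower number (0.77 log units; beyond the scatter) from compound 3 to compound 4; the limit leaves it open whether they differ Compound 3 reports only a limit, > 300000 nM, and it is not alone in this: the limit of > 300000 nM in this assay, at which 2 of the 4 values shown sit.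

Open, on these data alone, is whether the lower number belongs to chloro as such, or whether a fluoro, a bromo, a methoxy group or a nitrile on the same aromatic carbon would give a step of similar size on either core. Also open is how far the pendant ring sets the size of the step, since the compounds shown hold only a single fluoro and two chloro groups there and nothing such as an amine or a carboxylic acid.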